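The source may report more compounds than this note shows. Statements on the series, on what has been measured and on what is new or still open speak of the compounds shown alone.

In a functional assay on MGC-803 cells (Homo sapiens) for antiproliferative activity, read by MTT assay, with a stated time of 48 h (on this read-out lower numbers stand for stronger inhibition and higher numbers for weaker inhibition), compound 1 `CCCCCCCCn1cc(COC[C@@H]2OC[C@H](N)[C@@H]2O)nn1` gives 70400 nM and compound 2 `CCCCCCCCCCCCCCCCCCn1cc(COC[C@@H]2OC[C@H](N)[C@@H]2O)nn1` gives 15400 nM on the same read-out. Compound 3 `CCCCCCCCn1cc(COC[C@@H]2OC[C@H](N)[C@H]2O)nn1` stands at > 128000 nM and this value is a limit of the assay, not a number. Compound 4 `CCCCCCCCCCCCCCn1cc(COC[C@@H]2OC[C@H](N)[C@H]2O)nn1` is reached from compound 3 by one change (hexyl in place of hydrogen on a saturated chain carbon, eight bonds along the chain from an aromatic nitrogen), with hexyl in place of hydrogen on a saturated chain carbon, eight bonds along the chain from an aromatic nitrogen.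

Among the compounds with values here, two measured steps bear on this change. The closer one is a 4.6-fold lower number from compound 1 to compound 2 (0.66 log units; beyond the scatter), where decyl enters at the same chain carbon. Hexyl is the shorter addition, so a smaller step in the same direction is expected, although that precedent comes from the other configuration. The second is an at least 1.8-fold higher number from compound 1 to compound 3 (0.25 log units; that floor lies within the scatter), a change of configuration alone (the fact that compounds 1 and 3 differ only in the configuration as drawn) whose floor lies within the scatter. It suggests that compound 4 may stay on the weaker side of a close analogue in the series of compound 1.

A modest drop is therefore expected in this assay, estimated as an at least 2.5-fold lower number from compound 3 to compound 4 (0.40 log units; beyond the scatter) and counted from the limit. For compound 4 the estimated value is 50000 nM, with an expected range from 20000 nM to 128000 nM.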

Compound 4, half-maximal inhibitory concentration: 8790 nM
Compound 4: middle estimate off by 5.7-fold (0.75 log units), on the high side; measured number outside the range, below it.
By their numbers in this assay, from the lowest: compounds 4 and 2 (each within the scatter of the next); then compound 1. At a limit, above all of these: compound 3.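

In this assay, hexyl in place of hydrogen on a saturated chain carbon, eight bonds along the chain from an aromatic nitrogen, brings an at least 14-fold lower number from compound 3 to compound 4 (1.16 log units; beyond the scatter). Within the data shown here, the lower number that chain extension gave at this carbon, earlier seen only with decyl in the other configuration as a 4.6-fold lower number from compound 1 to compound 2 (0.66 log units; beyond the scatter), therefore also appears in the configuration of compound 3. Compound 3 stands at > 128000 nM, which is a limit of the assay and not a number, so the new step is a floor and its true size stays unknown: the limit of > 128000 nM in this assay, at which 1 of the 4 values shown sits.

What the configuration at the saturated ring carbon does once the chain is longer stays open, since the effect of configuration alone is shown only for the pair of compound 1 and compound 3, and that pair ends at a limit. Also open, going by these compounds, is how far the trend runs along the chain, and whether a longer chain still, or an amine or a carboxylic acid in place of the hexyl, would keep the number this low.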